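This account rests on a few compounds, and the source may have more. Where it says the series, first, only, none or still open, it means among the compounds named here.

In an assay on cells for inhibition of cytochrome P450 11B2, mitochondrial (Homo sapiens), read by HTRF (a higher number here means a weaker inhibitor, a lower number a stronger inhibitor), compound 1, `CCC(=O)N[C@@H]1CCCc2c1cncc2N1C(=O)c2ccc(Cl)cc2[C@@H]1C`, gives 6 nM. Compound 2, `CCC(=O)N[C@@H]1CCCc2c1cncc2N1C(=O)c2ccc(Cl)cc2[C@@H]1CC`, differs from compound 1 by methyl in place of hydrogen on a saturated chain carbon bound to a saturated ring carbon and in this assay compound 2 gives 12 nM, a step of a 2.0-fold higher number from compound 1 to compound 2 (0.30 log units; within the scatter). Compound 3, `CC1(C)c2cc(Cl)ccc2C(=O)N1c1cncc(CNS(C)(=O)=O)c1`, is built on a different core, and the difference between the two cores is not broken down here. In this assay, going by the values given here, compound 3 gives 33 nM, the highest of the three numbers so far. Compound 4, `C[C@@H](NS(C)(=O)=O)c1cncc(N2C(=O)c3ccc(Cl)cc3C2(C)C)c1`, has not yet been measured. It differs from compound 3 by methyl in place of hydrogen on a saturated chain carbon bound to an aromatic carbon and a sulfonamide nitrogen. Among the compounds with values here, this is the same kind of change as the one between compound 1 and compound 2, but not the same: here the carbon that takes the methyl is bound to an aromatic carbon and a sulfonamide nitrogen, whereas before it was bound to a saturated ring carbon. Within the data shown here, only one earlier step of this kind is known, so for compound 4 a step of about a 1.4-fold higher number from compound 3 to compound 4 (0.13 log units; within the scatter) in this assay is expected, because a 2.0-fold higher number from compound 1 to compound 2 (0.30 log units; within the scatter) stayed within the scatter. Compound 4 is therefore estimated at 45 nM, most likely between 15 nM and 150 nM.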

Compound 4, half-maximal inhibitory concentration: 8 nM
Beside the measured number, compound 4's estimate is 5.6-fold (0.75 log units) above it; measured number outside the range, below it.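

In this assay the methyl in place of hydrogen gives a 4.1-fold lower number from compound 3 to compound 4 (0.62 log units; beyond the scatter) and so makes compound 4 the stronger inhibitor of the pair. The same kind of change therefore does not carry over between these two cores with a fixed size or direction: the same change on two cores in this assay, a 2.0-fold higher number (0.30 log units; within the scatter) from compound 1 to compound 2 and a 4.1-fold lower number (0.62 log units; beyond the scatter) from compound 3 to compound 4, 8.3-fold (0.92 log units) apart, beyond the scatter of two such steps. This does not show which difference between the pairs sets the steps apart, as the core and the atoms bound to the carbon taking the methyl both differ, and two pairs cannot separate these or predict the step on a third core.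

The compounds shown leave open whether the gain in compound 4 is specific to methyl or would also appear with a longer chain such as propyl, or with an amine or a hydroxyl group on the same carbon. They also leave open whether methyl on a saturated chain carbon bound to an aromatic carbon and a sulfonamide nitrogen would give a similar step on the core of compound 1.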